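A Methyl on the Sulfonamide Nitrogen, Seen Twice

The source may report more compounds than this note shows. Statements on the series, on what has been measured and on what is new or still open speak of the compounds shown alone.

In a functional assay on the whole organism for inhibition, with Canis familiaris (Canis lupus familiaris) as the target (a lower number here means that less compound is needed, a higher number that more compound is needed for the effect), compound 1 `CCN1CCCC1CNC(=O)c1cc(N(C)S(C)(=O)=O)c(Cl)cc1OC` gives 0.1 mg/kg, and compound 2 `CCN1CCCC1CNC(=O)c1cc(NS(C)(=O)=O)c(Cl)cc1OC` gives 0.1 mg/kg. The two differ by a single change, (methyl in place of hydrogen on a sulfonamide nitrogen), and the step of no change at the digits printed from compound 2 to compound 1 (within the scatter) lies within the scatter. Compound 3 `CCN1CCCC1CNC(=O)c1cc(NS(N)(=O)=O)ccc1OC` gives 10 mg/kg in this assay; how its core differs from that of compound 2 is not broken down here. Compound 4 `CCN1CCCC1CNC(=O)c1cc(N(C)S(N)(=O)=O)ccc1OC` is not yet measured. It differs from compound 3 by methyl in place of hydrogen on a sulfonamide nitrogen, the same change in the same place, since the sulfonamide nitrogen again has an aromatic carbon and a sulfonyl sulfur as its other neighbours. Because no change at the digits printed from compound 2 to compound 1 (within the scatter) showed no effect of this change, the step of no change at the digits printed from compound 3 to compound 4 (within the scatter) is expected to be similarly small. Compound 4 is therefore estimated at 10 mg/kg, with a likely range from 4 mg/kg to 25 mg/kg.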

Compound 4, dose for half-maximal effect: 1 mg/kg
Estimate against measurement, compound 4: 10-fold (1.00 log units) above, outside the stated range (below it).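

In this assay, methyl in place of hydrogen on the sulfonamide nitrogen gives a 10-fold lower number from compound 3 to compound 4 (1.00 log units; beyond the scatter), so this change does not carry over from one core to the other with the same size of step: the same change on two cores in this assay, no change at the digits printed (within the scatter) from compound 2 to compound 1 and a 10-fold lower number (1.00 log units; beyond the scatter) from compound 3 to compound 4, 10-fold (1.00 log units) apart, beyond the scatter of two such steps Compound 2 and compound 3 differ in more than one place, and these two pairs alone do not show which of those differences sets the two steps apart. With one pair on each core, they also give no general rule for this change across the series.

The compounds shown leave open what a longer chain, such as ethyl, would do on this sulfonamide nitrogen on either core. They also leave open how an acetyl group would compare there.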